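This account rests on a few compounds, and the source may have more. Where it says the series, first, only, none or still open, it means among the compounds named here.

Measured so far in a physicochemical assay for solubility, with a stated time of 4 h, at pH 7.4; on this read-out higher numbers stand for higher solubility and lower numbers for lower solubility:
- compound 1 `Cc1cc(CCC#N)cc(C)c1Oc1cc(Nc2ccc(C#N)cc2)c(N)cc1CO`: 18.8 ug/mL
- compound 2 `Cc1cc(/C=C/C#N)cc(C)c1Oc1cc(Nc2ccc(C#N)cc2)c(N)cc1C(F)(F)F`: 0.24 ug/mL

Of these two compounds, compound 2 stands lowest at 0.24 ug/mL, and the gap up to compound 1 lies well beyond the usual scatter of repeated measurements. Compound 3 `Cc1cc(/C=C/C#N)cc(C)c1Oc1cc(Nc2ccc(C#N)cc2)c(N)cc1CO` is still unmeasured. It keeps everything in compound 2 except one group, with hydroxymethyl in place of trifluoromethyl on an aromatic carbon.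

Among the compounds with values here, no measured pair shows this change alone, since compound 1 and compound 2 differ in more than one place. Within the data shown here, the only guide is therefore indirect. Compound 1 also carries hydroxymethyl, and in this assay compound 1 gives 18.8 ug/mL. On that basis, compound 3 is expected to rise clearly above compound 2, beyond the scatter, while part of the gap between the two measured compounds may remain. The expected change is a 17-fold higher number from compound 2 to compound 3 (1.22 log units; beyond the scatter). For compound 3 the estimate is 4 ug/mL, with an expected range from 0.8 ug/mL to 20 ug/mL.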

Compound 3, solubility: 3.23 ug/mL
Beside the measured number, compound 3's estimate is 1.2-fold (0.09 log units) above it; measured number inside the range.
By their numbers in this assay, from the lowest: compound 2; then compound 3; then compound 1.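

In this assay, the comparison of compound 2 with compound 3 isolates a single change on the aromatic carbon para to the (4-cyanophenyl)amino group: hydroxymethyl in place of trifluoromethyl gives a 13-fold higher number from compound 2 to compound 3 (1.13 log units; beyond the scatter) and so counts as a large step on its own. With hydroxymethyl held fixed, 2-cyanoethenyl in place of 2-cyanoethyl gives a 5.8-fold lower number from compound 1 to compound 3 (0.76 log units; beyond the scatter) as a modest step, which shows that the wide difference between the two earlier compounds does not come from the change at this position alone. Nothing measured here explains what lies behind either step.

The compounds shown compare only hydroxymethyl and trifluoromethyl at this position, so they leave open where an amine, a carboxylic acid, or a longer chain such as 2-hydroxyethyl would fall on this read-out. They also leave open whether swapping trifluoromethyl for hydroxymethyl would produce a step of similar size in a compound carrying 2-cyanoethyl rather than 2-cyanoethenyl.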